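Methyl on the Shared Core and Cell Cytotoxicity

The source may report more compounds than this note shows. Statements on the series, on what has been measured and on what is new or still open speak of the compounds shown alone.

Compound 1, `Clc1ccc(C2ON=C(c3ccccc3Cl)O2)cc1`, in an ADME assay on HEK293 cells (Homo sapiens) for cytotoxicity, read by MTT assay, with a stated time of 44 h (on this read-out higher numbers stand for weaker inhibition and lower numbers for stronger inhibition), gives > 100000 nM, which is a limit of the assay and not a number.
Compound 2, `CC1(c2ccc(Cl)cc2)ON=C(c2ccccc2Cl)O1`, in this assay gives > 100000 nM, again a limit rather than a number.
Compound 3, `Clc1ccc(C2=NOC(c3ccc(Cl)cc3)O2)cc1`, in this assay gives > 100000 nM, also a limit and not a number.

All three measured compounds therefore sit at the limit of > 100000 nM in this assay, at which 3 of the 3 values shown sit, and none of them shows measurable cytotoxicity in this assay within the range the assay covers.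

Compound 1 and compound 3 are built from the same atoms joined differently; how the two cores differ is not broken down here. Compound 2 arises from compound 1 by methyl in place of hydrogen on a saturated ring carbon. The step that the two limits leave unreadable from compound 1 to compound 2 cannot be read, since both ends are limits.

Compound 4, `CC1(c2ccc(Cl)cc2)ON=C(c2ccc(Cl)cc2)O1`, has not yet been measured in this assay. For the measured compounds named here, it arises from compound 3 by methyl in place of hydrogen on a saturated ring carbon, the same change at the same place as the one from compound 1 to compound 2.

Going by the values given here, the step from compound 3 to compound 4 is expected to be a step that the limit leaves unreadable from compound 3 to compound 4, and this expectation rests on the fact that compound 1, compound 2 and compound 3 all sit at the limit of > 100000 nM in this assay, at which 3 of the 3 values shown sit, so that the methyl brought no readable change in the one measured pair. Compound 4 is therefore expected to give about 200000 nM, most likely reported as a limit, with a range from 90000 nM to 500000 nM.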

Compound 4, half-maximal inhibitory concentration: > 100000 nM
Compound 4: no number, only a limit (the forecaster's own chance of this, stated with the estimate: 85%); the middle value is on the limit's open side.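

Compound 3 and compound 4 both end at a limit and not at a number, so no size can be read for the methyl step between them, and the four compounds stand level in this respect: the limit of > 100000 nM in this assay, at which 4 of the 4 values shown sit.

As far as these compounds go, what stays open is whether methyl in place of hydrogen on a saturated ring carbon changes anything in this assay, and at what concentration, if any, these compounds would become toxic to the cells.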